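The source may hold more compounds than are shown below. What is called first, only, known or untested is meant among the compounds shown, and "the series" means these compounds.

Compound 1 `CC[C@@H]1C(=O)N(C)c2cnc(Nc3ccc(S(=O)(=O)NC4CCCC4)cc3)nc2N1C1CCCC1` is a sulfonamide; in a functional assay on HeLa cells (Homo sapiens) for antiproliferative activity, read by CCK-8 assay, with a stated time of 72 h (on this read-out lower numbers stand for stronger inhibition of growth and higher numbers for weaker inhibition of growth), compound 1 gives 609 nM. Its companion compound 2 `CCNC(=O)c1ccc2c(ccn2-c2ncc3c(n2)N(C2CCCC2)[C@H](CC)C(=O)N3C)c1` gives 418 nM in this assay, and the two numbers sit within the scatter of one another, so neither stands apart. Compound 3 `CC[C@@H]1C(=O)N(C)c2cnc(Nc3ccc(S(=O)(=O)NCC(C)C)cc3)nc2N1C1CCCC1` keeps the core of compound 1 and differs in one place: isobutyl in place of cyclopentyl on a sulfonamide nitrogen. Among the measured compounds shown here, no measured pair shows what this change does, so the step expected in this assay is a 1.0-fold lower number from compound 1 to compound 3 (0.01 log units; within the scatter), nothing beyond the scatter in either direction. Compound 3 is therefore expected to give about 600 nM in this assay, most likely between 250 nM and 1500 nM.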

Compound 3, concentration for 50% growth inhibition: 561 nM
Beside the measured number, compound 3's estimate is 1.1-fold (0.03 log units) above it; measured number inside the range.
By their numbers in this assay, from the lowest: compounds 2, 3 and 1 (each within the scatter of the next).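

Swapping cyclopentyl for isobutyl on the sulfonamide nitrogen gives the first measured step at this position: in this assay it is a 1.1-fold lower number from compound 1 to compound 3 (0.04 log units; within the scatter). For this pair, then, the five-membered ring can give way to the open branched chain, with one carbon fewer, without the number moving beyond the scatter. No available evidence bears on why the two numbers stay so close. The compounds shown leave open whether an amine, a carboxylic acid or a longer chain on this nitrogen would also stay within the scatter of compound 1.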